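Amide nitrogen variation in a dopamine transporter series

This account rests on a few compounds, and the source may have more. Where it says the series, first, only, none or still open, it means among the compounds named here.

Measured so far:
compound 1 `O=C(C1=C(c2ccc(Cl)c(Cl)c2)CCC1)N1CCCC1`: 58000 nM
compound 2 `CON(C)C(=O)C1=C(c2ccc(Cl)c(Cl)c2)CCC1`: 6400 nM

Both compounds share one core and differ only in the group on the carbonyl carbon. In an assay on COS-1 cells for displacement of a labelled ligand from sodium-dependent dopamine transporter (Homo sapiens) (a lower number here means a stronger inhibitor, a higher number a weaker inhibitor), compound 1 gives 58000 nM, while compound 2 gives 6400 nM. Within the data shown here, the single measured step, a 9.1-fold lower number from compound 1 to compound 2 (0.96 log units; beyond the scatter), shows that the group on the carbonyl carbon moves the number by a modest amount. Among the measured compounds shown here, compound 2 therefore stands at the lowest of the two numbers; compound 1, its only neighbour, sits higher by that step, which lies beyond the scatter.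

Compound 3 `O=C(NCc1cccs1)C1=C(c2ccc(Cl)c(Cl)c2)CCC1` carries the change (((thiophen-2-yl)methyl)amino in place of methoxy(methyl)amino on a carbonyl carbon). For the measured compounds named here, no measured step covers an amide bearing a hydrogen on its nitrogen, nor an aromatic ring in the amine part. Going by the values given here, the only step bearing on this position is the one above, and it sets the scale of what a change here has done so far. Among the compounds with values here, a value near that of compound 2 is expected, with a wide range to reflect the single reference step. The expected value for compound 3 is 10000 nM, with a range from 2000 nM to 60000 nM. This estimate means a 1.6-fold higher number from compound 2 to compound 3 (0.19 log units; within the scatter), expected to stay within the scatter.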

Compound 3, inhibition constant: 140 nM
Estimate against measurement, compound 3: 71-fold (1.85 log units) above; the measured number lies below the stated range.
By their numbers in this assay, from the lowest: compound 3; then compound 2; then compound 1.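

In this assay, among these compounds, the step of a 46-fold lower number from compound 2 to compound 3 (1.66 log units; beyond the scatter) shows that the group on the carbonyl carbon can move the number much further than the earlier step of a 9.1-fold lower number from compound 1 to compound 2 (0.96 log units; beyond the scatter) indicated, and the full span of the position so far is the step of a 410-fold lower number from compound 1 to compound 3 (2.62 log units; beyond the scatter). Of the three amine parts, only ((thiophen-2-yl)methyl)amino has a hydrogen-bond donor and a five-membered aromatic ring, and it gives the lowest number, so this position is not limited to the modest effect seen between the pyrrolidin-1-yl and methoxy(methyl)amino amides. No measurement available here explains the size of this shift.

The donor and the thiophene ring enter together in compound 3, so the compounds shown do not assign the large step to either feature or to the larger size of the group. On these data alone, it remains open how the number would respond to a benzylamino group in place of the (thiophen-2-yl)methylamino group, to a methyl on the amide nitrogen of compound 3, or to a longer chain between that nitrogen and the thiophene ring.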